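Ester side chain: sulfur-linked phenyl to direct phenyl

A few compounds are considered here, and "the series" means these few. Any claim that something is new, unique, unknown or untested is made for them only; others in the source may bear on it.

Going by the values given here, compound 2 `CCCc1nc(CC)c(C(=O)OCc2ccccc2Sc2ccccc2)n1Cc1ccc(-c2ccccc2S(=O)(=O)NC(=O)OCCC(C)C)cc1F` gives the lower of the two numbers so far in an assay on isolated protein for binding affinity to Type-2 angiotensin II receptor (Homo sapiens) (a lower number here means a stronger inhibitor, a higher number a weaker inhibitor), at 2 nM. Among the compounds with values here, compound 1 `CCCc1nc(CC)c(C(=O)OCCN2C(=O)c3ccccc3C2=O)n1Cc1ccc(-c2ccccc2S(=O)(=O)NC(=O)OCCC(C)C)cc1F`, the only other measured compound, gives 7 nM in this assay, a gap beyond the scatter. Compound 3 `CCCc1nc(CC)c(C(=O)OCc2ccccc2-c2ccccc2)n1Cc1ccc(-c2ccccc2S(=O)(=O)NC(=O)OCCC(C)C)cc1F` is not yet measured; it differs from compound 2 by phenyl in place of phenylsulfanyl on an aromatic carbon. Within the data shown here, no measured pair shows this change, so the step in this assay is expected to be modest, toward a slightly higher number or none beyond the scatter, as a 1.5-fold higher number from compound 2 to compound 3 (0.18 log units; within the scatter). Compound 3 is expected to give 3 nM, within 1 nM to 9 nM.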

Compound 3, half-maximal inhibitory concentration: 9 nM
Estimate against measurement, compound 3: 3.0-fold (0.48 log units) below, and the stated range covers the measured number.
By their numbers in this assay, from the lowest: compound 2; then compounds 1 and 3 (each within the scatter of the next).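

In this assay, the single atom of sulfur counts at this position: phenyl in place of phenylsulfanyl gives a 4.5-fold higher number from compound 2 to compound 3 (0.65 log units; beyond the scatter). Exchanging the whole ester side chain gives only a 1.3-fold higher number from compound 1 to compound 3 (0.11 log units; within the scatter), so these two quite different side chains cannot be told apart here. Nothing measured on these compounds bears on why the sulfur link makes a difference. As far as these compounds go, whether an oxygen or a methylene link in place of the sulfur would match compound 2 remains open. So does the effect of an amine on the outer phenyl ring.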